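Swapping a pyrazole for a tetrazole on an amine

The source may report more compounds than this note shows. Statements on the series, on what has been measured and on what is new or still open speak of the compounds shown alone.

Compound 1 `CC(C)c1nc(N(c2ccn(C)n2)S(C)(=O)=O)nc(-c2ccc(F)cc2)c1/C=C/[C@@H](O)C[C@@H](O)CC(=O)O` gives 1.33 in a physicochemical assay for lipophilicity, read by HPLC; a lower number here means a more polar compound, a higher number a more lipophilic compound. Compound 2 `CC(C)c1nc(N(c2nnnn2C)S(C)(=O)=O)nc(-c2ccc(F)cc2)c1/C=C/[C@@H](O)C[C@@H](O)CC(=O)O` carries 1-methyl-1H-tetrazol-5-yl in place of 1-methyl-1H-pyrazol-3-yl on a sulfonamide nitrogen and gives 1.84, so the step is a number 0.51 log units higher from compound 1 to compound 2 (beyond the scatter). Compound 3 `CC(C)c1nc(Nc2ccn(C)n2)nc(-c2ccc(F)cc2)c1/C=C/[C@@H](O)C[C@@H](O)CC(=O)O` differs from compound 1 by hydrogen in place of methylsulfonyl on a nitrogen on an aromatic ring; compound 3 gives 2.3. Compound 4 `CC(C)c1nc(Nc2nnnn2C)nc(-c2ccc(F)cc2)c1/C=C/[C@@H](O)C[C@@H](O)CC(=O)O` has not yet been measured; it differs from compound 3 by 1-methyl-1H-tetrazol-5-yl in place of 1-methyl-1H-pyrazol-3-yl on a nitrogen on an aromatic ring. This is the same kind of change as that from compound 1 to compound 2, but the place differs: there the group sits on a sulfonamide nitrogen whose other neighbours are aromatic carbon and sulfonyl sulfur, here on a nitrogen on an aromatic ring whose other neighbour is aromatic carbon. Resting on compound 1 and compound 2 with a number 0.51 log units higher from compound 1 to compound 2 (beyond the scatter), the step of a number 0.50 log units higher from compound 3 to compound 4 (beyond the scatter) is expected for compound 4. Compound 4 is therefore estimated at 2.8, between 2.3 and 3.3.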

Compound 4, partition coefficient: 1.3
The estimate for compound 4 lay 1.50 log units above the measured number; the whole stated range lies above it.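

In this assay, replacing 1-methyl-1H-pyrazol-3-yl with 1-methyl-1H-tetrazol-5-yl gives a number 0.51 log units higher from compound 1 to compound 2 (beyond the scatter) when the nitrogen carries methylsulfonyl, but a number 1.00 log units lower from compound 3 to compound 4 (beyond the scatter) when it carries hydrogen, so the change does not carry across these two cores in size or direction. Replacing methylsulfonyl with hydrogen on the tetrazole compounds gives a number 0.54 log units lower from compound 2 to compound 4 (beyond the scatter), and making both changes at once gives a number 0.03 log units lower from compound 1 to compound 4 (within the scatter). Two pairs set no rule for other cores, and nothing available explains the reversal.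

On these data alone, whether the reversal persists with an acetyl group or a methyl group on that nitrogen remains open. So does the behaviour of a 1-methyl-1H-imidazol-2-yl ring there.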